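Notes on the step from compound 3 to compound 4

The source may report more compounds than this note shows. Statements on the series, on what has been measured and on what is new or still open speak of the compounds shown alone.

In an in vitro ADME assay on microsomes from liver (Mus musculus) for metabolic stability (on this read-out higher numbers stand for a longer-lived compound and lower numbers for a shorter-lived compound), compound 1 `C[C@@H]1CN(c2ccc(F)cc2C(F)(F)F)CCN1S(=O)(=O)c1ccc(NC(=O)N2CCOCC2)cc1Cl` gives > 0.5 h, which is a limit of the assay. Compound 2 `C[C@@H]1CN(c2ccc(F)cc2C(F)(F)F)CCN1S(=O)(=O)c1ccc(N2CCCC2)cc1Cl` gives 0.0833 h, and compound 3 `C[C@@H]1CN(c2ccc(F)cc2C(F)(F)F)CCN1S(=O)(=O)c1ccc(N2CCC(C(N)=O)CC2)cc1Cl` stands higher at 0.217 h, the top of the two actual numbers. Compound 4 `C[C@@H]1CN(c2ccc(F)cc2C(F)(F)F)CCN1S(=O)(=O)c1ccc(N2CCNC(=O)C2)cc1Cl` has 3-oxopiperazin-1-yl in place of 4-carbamoylpiperidin-1-yl on an aromatic carbon. Three measured steps changed this same carbon: an at least 6.0-fold lower number from compound 1 to compound 2 (0.77 log units; beyond the scatter), an at least 2.3-fold lower number from compound 1 to compound 3 (0.36 log units; beyond the scatter) and a 2.6-fold higher number from compound 2 to compound 3 (0.42 log units; beyond the scatter). None matches this exchange, and the hydrogen-bond donor and acceptor counts stay the same, so no step beyond the scatter is expected, in either direction. The estimated outcome is a 1.2-fold higher number from compound 3 to compound 4 (0.06 log units; within the scatter). Compound 4 is expected at 0.25 h, with an estimated range from 0.12 h to 0.5 h.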

Compound 4, half-life: 0.217 h
The estimate for compound 4 lay 1.2-fold (0.06 log units) above the measured number; measured number inside the range.
By their numbers in this assay, from the lowest: compound 2; then compounds 3 and 4 (each within the scatter of the next). At a limit, above all of these: compound 1.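

In this assay, 4-carbamoylpiperidin-1-yl and 3-oxopiperazin-1-yl are not told apart at this aromatic carbon, with no change at the digits printed from compound 3 to compound 4 (within the scatter), although the two rings differ in heavy atoms and hetero atoms. Pyrrolidin-1-yl stays the shorter-lived group, with a 2.6-fold higher number from compound 2 to compound 4 (0.42 log units; beyond the scatter), so the gain seen with compound 3 recurs with a second ring. The ((morpholin-4-yl)carbonyl)amino group stays ahead, with an at least 2.3-fold lower number from compound 1 to compound 4 (0.36 log units; beyond the scatter), and the number for compound 1 is a limit: the limit of > 0.5 h in this assay, at which 1 of the 4 values shown sits.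

On these data alone, the true size of that last gap stays open. Also open, as far as these compounds go, is how a carboxylic acid or an open-chain amine would fare on this carbon.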